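The source may hold more compounds than are shown below. What is called first, only, known or untested is meant among the compounds shown, and "the series" means these compounds.

In a functional assay on SMMC-7721 cells (Homo sapiens) for inhibition, read by MTT assay, with a stated time of 48 h (on this read-out higher numbers stand for weaker inhibition and lower numbers for stronger inhibition), compound 1 `CN(c1ncccc1CNc1nc(Nc2ccc(F)cc2)nc2[nH]cc(F)c12)S(C)(=O)=O` gives 27900 nM, and compound 2 `COc1ccc(Nc2nc(NCc3cccnc3N(C)S(C)(=O)=O)c3c(F)c[nH]c3n2)cc1OC` gives 54800 nM, a step of a 2.0-fold higher number from compound 1 to compound 2 (0.29 log units; within the scatter). Compound 3 `COc1cc(Nc2nc(NCc3cccnc3N(C)S(C)(=O)=O)c3c(F)c[nH]c3n2)cc(OC)c1OC` reaches only a limit of this assay, recorded as > 100000 nM, so its standing is a limit and not a number. Set against compound 1 the step is an at least 3.5-fold higher number from compound 1 to compound 3 (0.55 log units; beyond the scatter), and against compound 2 it is an at least 1.8-fold higher number from compound 2 to compound 3 (0.26 log units; that floor lies within the scatter). Compound 4 `CC(=O)NCc1cccc(Nc2nc(NCc3cccnc3N(C)S(C)(=O)=O)c3c(F)c[nH]c3n2)c1` is not yet measured; it carries 3-(acetamidomethyl)phenyl in place of 3,4,5-trimethoxyphenyl on a nitrogen on an aromatic ring. Since the earlier exchanges of this group shifted this assay only modestly or within the scatter across compounds 1, 2 and 3, compound 4 is expected to remain in the same weak region, an estimated step of an at least 1.6-fold lower number from compound 3 to compound 4 (0.22 log units; that floor lies within the scatter). The estimate for compound 4 is 60000 nM, between 20000 nM and 150000 nM.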

Compound 4, half-maximal inhibitory concentration: 21700 nM
Estimate against measurement, compound 4: 2.8-fold (0.44 log units) above, and the stated range covers the measured number.
By their numbers in this assay, from the lowest: compounds 4, 1 and 2 (each within the scatter of the next, the first and the last beyond it). At a limit, above all of these: compound 3.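

In this assay the 3-(acetamidomethyl)phenyl group gives an at least 4.6-fold lower number from compound 3 to compound 4 (0.66 log units; beyond the scatter) and a 2.5-fold lower number from compound 2 to compound 4 (0.40 log units; beyond the scatter) against the methoxy-bearing rings, so this position accepts a chain with an amide hydrogen better than those rings. Against 4-fluorophenyl the same change gives a 1.3-fold lower number from compound 1 to compound 4 (0.11 log units; within the scatter) and so no real gain. The first step is only a floor; compound 3 stands at a limit, not a number: the limit of > 100000 nM in this assay, at which 1 of the 4 values shown sits.

As far as these compounds go, whether an amine or a carboxylic acid in place of the acetamide, or a longer chain, would bring the number lower stays open.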